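The compounds below may be only part of what the source reports. "The series", "measured", "known", "first", "only" and "open" are said of these compounds alone.

Measured so far in an ADME assay on a cell-free system (plasma, Mus musculus) for metabolic stability, read by LC-MS, with a stated time of 2 h, tested at 2 uM; on this read-out lower numbers stand for a shorter-lived compound and higher numbers for a longer-lived compound
compound 1 (`NC1CCc2nc(-c3ccncc3)nc(Nc3cccc(F)c3)c2C1`) gives > 2 h
compound 2 (`CN(C)c1ccc(Nc2nc(-c3ccncc3)nc3c2CC(N)CC3)cc1`) gives > 2 h
compound 3 (`COc1cccc(Nc2nc(-c3ccncc3)nc3c2CC(N)CC3)c1`) gives > 2 h

Compound 1 stands at a limit and not at a number, with > 2 h as its only entry. The whole set sits in the same place (the limit of > 2 h in this assay, at which 3 of the 3 values shown sit).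

Next is compound 4 (`NC1CCc2nc(-c3cccnc3)nc(Nc3cccc(F)c3)c2C1`), which has the same atoms as compound 1, joined differently (pyridin-3-yl in place of pyridin-4-yl on an aromatic carbon). Pyridin-3-yl enters in place of pyridin-4-yl on an aromatic carbon, between two ring nitrogen atoms.

The measured steps (a step that the two limits leave unreadable from compound 1 to compound 2), (a step that the two limits leave unreadable from compound 1 to compound 3) and (a step that the two limits leave unreadable from compound 2 to compound 3) give no size, and all three keep pyridin-4-yl in place. None of them tests this change directly. Within the data shown here, the only anchor is compound 1 at > 2 h as a limit. No step beyond the scatter is expected in this assay, and no direction can be assigned. The expected step is small (a step that the limit leaves unreadable from compound 1 to compound 4). Compound 4 is expected at 3 h with an estimated range of 1.5 h to 6 h and will most likely be reported as a limit again.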

Compound 4, half-life: > 2 h
Compound 4: only a limit was reported (the forecaster's own chance of this, stated with the estimate: 85%); the middle value does not contradict the limit.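

No step can be read between compound 1 and compound 4 in this assay, because both are reported as a limit and not as a number: the limit of > 2 h in this assay, at which 4 of the 4 values shown sit.

The compounds shown leave open the actual half-life of each compound, and so whether pyridin-3-yl in place of pyridin-4-yl makes any difference.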